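The source may hold more compounds than are shown below. What is called first, only, known or untested is meant among the compounds shown, and "the series" means these compounds.

Three compounds share one core and differ only in the aryl group carried on a nitrogen on an aromatic ring. Compound 1 `C=CC(=O)Nc1cccc(NC(=O)CSc2nc(Nc3ccccc3Cl)c3ccccc3n2)c1` gives 12700 nM in a functional assay on MDA-MB-231 cells (Homo sapiens) for inhibition, read by MTT assay, with a stated time of 72 h; a higher number here means a weaker inhibitor, a lower number a stronger inhibitor; compound 2 `C=CC(=O)Nc1cccc(NC(=O)CSc2nc(Nc3cccc(Cl)c3)c3ccccc3n2)c1` gives 16300 nM in this assay; compound 3 `C=CC(=O)Nc1cccc(NC(=O)CSc2nc(Nc3ccc(F)cc3)c3ccccc3n2)c1` gives 9490 nM in this assay. Compound 3 stands at one end of these three numbers, yet its separation from the others is small: a 1.3-fold lower number from compound 1 to compound 3 (0.13 log units; within the scatter) and a 1.7-fold lower number from compound 2 to compound 3 (0.23 log units; within the scatter), and a 1.3-fold higher number from compound 1 to compound 2 (0.11 log units; within the scatter) is of the same kind. Compound 4 `C=CC(=O)Nc1cccc(NC(=O)CSc2nc(Nc3ccc(Cl)c(Cl)c3)c3ccccc3n2)c1` has not been measured; it arises from compound 3 by 3,4-dichlorophenyl in place of 4-fluorophenyl on a nitrogen on an aromatic ring. The measured steps that bear on this change are the exchanges among halogenated phenyl groups on the same nitrogen, which moved this assay by a 1.3-fold lower number from compound 1 to compound 3 (0.13 log units; within the scatter) and by a 1.7-fold lower number from compound 2 to compound 3 (0.23 log units; within the scatter), both within the scatter. No step beyond the scatter is therefore expected for compound 4, whose number in this assay is estimated at 9000 nM, within a range from 4000 nM to 20000 nM, which amounts to an expected step of a 1.1-fold lower number from compound 3 to compound 4 (0.02 log units; within the scatter).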

Compound 4, half-maximal inhibitory concentration: 17700 nM
Compound 4: the middle estimate sits 2.0-fold (0.29 log units) below what was measured; measured number inside the range.
By their numbers in this assay, from the lowest: compounds 3, 1, 2 and 4 (each within the scatter of the next).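

In this assay the 3,4-dichlorophenyl group leaves this position as flat as before, both against 4-fluorophenyl (a 1.9-fold higher number from compound 3 to compound 4 (0.27 log units; within the scatter)) and against 2-chlorophenyl (a 1.4-fold higher number from compound 1 to compound 4 (0.14 log units; within the scatter)). New here is a step that adds a halogen instead of exchanging one: chloro in place of hydrogen on an aromatic carbon (a 1.1-fold higher number from compound 2 to compound 4 (0.04 log units; within the scatter)) stays within the scatter, so a second chlorine on the phenyl group gives no readable change in this assay. Nothing available explains why the number responds so little to the halogen pattern.

On these data alone, all four compounds carry only fluoro or chloro on the phenyl group, so what a methoxy group, an amine or a carboxylic acid would do on that ring stays open. Since every step here lies within the scatter, the compounds also leave open whether any aryl group on this nitrogen can move the number beyond it.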